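The source may report more compounds than this note shows. Statements on the series, on what has been measured and on what is new or still open speak of the compounds shown alone.

Compound 1 `CC(C)=CCC/C(C)=C/CC/C(C)=C/CSC[C@H](NC(=O)CCCCCN1CCCC1)C(=O)NC1CCCCC1`, compound 2 `CC(C)=CCC/C(C)=C/CC/C(C)=C/CSC[C@H](NC(=O)CCCCCN1CCCC1)C(=O)N1CCCCC1` and compound 3 `CC(C)=CCC/C(C)=C/CC/C(C)=C/CSC[C@H](NC(=O)CCCCCN1CCN(C)CC1)C(=O)N1CCCCC1` share one core and differ only in the groups at its two amide ends. In a functional assay on BXPC-3 cells (Homo sapiens) for cytotoxicity, read by fluorescence, with a stated time of 48 h (a higher number here means that more compound is needed for the effect, a lower number that less compound is needed), compound 2 gives 8700 nM, compound 3 gives 8800 nM and compound 1 gives 12700 nM. Compound 2 therefore lies within the scatter of both other compounds, and these numbers set no order among them.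

The next compound, compound 4 `CC(C)=CCC/C(C)=C/CC/C(C)=C/CSC[C@H](NC(=O)CCCCCN1CCCC1)C(=O)N1CCCC1`, alters compound 2 in one place: pyrrolidin-1-yl in place of piperidin-1-yl on a carbonyl carbon. In words, pyrrolidin-1-yl stands in place of piperidin-1-yl on a carbonyl carbon.

The most relevant measured change sits on that same carbonyl carbon: putting piperidin-1-yl in place of cyclohexylamino gave a 1.5-fold lower number from compound 1 to compound 2 (0.16 log units; within the scatter). A change elsewhere, 4-methylpiperazin-1-yl in place of pyrrolidin-1-yl on a saturated chain carbon, gave a 1.0-fold higher number from compound 2 to compound 3 (0.00 log units; within the scatter). Going by the values given here, neither step left the scatter, although no measured pair carries this exact swap. No step beyond the scatter is therefore expected in this assay, and no direction can be favoured. The expected size of the change is a 1.0-fold higher number from compound 2 to compound 4 (0.01 log units; within the scatter). The estimated value for compound 4 is 9000 nM, with an expected range from 5000 nM to 16000 nM.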

Compound 4, half-maximal effective concentration: 6500 nM
Beside the measured number, compound 4's estimate is 1.4-fold (0.14 log units) above it, within the range that was stated.
By their numbers in this assay, from the lowest: compounds 4, 2, 3 and 1 (each within the scatter of the next).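

In this assay, putting a five-membered ring in place of a six-membered ring on the carbonyl carbon leaves the number within the usual scatter (a 1.3-fold lower number from compound 2 to compound 4 (0.13 log units; within the scatter)). The largest step at this position, between cyclohexylamino and pyrrolidin-1-yl, also stays within the scatter (a 2.0-fold lower number from compound 1 to compound 4 (0.29 log units; within the scatter)), so all three groups seen on this carbonyl carbon give numbers that cannot be told apart in this assay. These results set no order among the groups, and no accompanying evidence explains how the groups behave at this position.

From the compounds shown here alone, it remains open whether a different kind of group at this position, such as morpholin-4-yl or a carboxylic acid in place of the amide, would give a step beyond the scatter. Also open is how 4-methylpiperazin-1-yl on the saturated chain behaves with a group other than piperidin-1-yl on the carbonyl carbon, since those two groups appear together only in compound 3 among the compounds shown.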